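Swapping One Phenyl Substituent on a Shared Core

A few compounds are considered here, and "the series" means these few. Any claim that something is new, unique, unknown or untested is made for them only; others in the source may bear on it.

Of the compounds shown here, three built on one shared core have been tested in an assay on isolated protein for inhibition of DNA topoisomerase 1 (Homo sapiens), tested at 100 uM; a lower number here means a weaker effect, a higher number a stronger effect of the compound at the concentration tested. Compound 1 `Cc1ccc(-c2cc(-c3ccc(Cl)o3)cc(-c3ccsc3)n2)o1` gives 9.1%, compound 2 `Clc1ccc(-c2cc(-c3ccc(Cl)o3)cc(-c3ccsc3)n2)cc1` gives 29.8%, and compound 3 `Clc1cccc(-c2cc(-c3ccc(Cl)o3)cc(-c3ccsc3)n2)c1` gives 0%, the lowest of the three numbers. Compound 4 `Cc1ccc(-c2cc(-c3ccc(Cl)o3)cc(-c3ccsc3)n2)cc1` differs from compound 3 in one place: 4-methylphenyl in place of 3-chlorophenyl on an aromatic carbon. The measured step that bears most on this change is a number 29.8 percentage points lower from compound 2 to compound 3 (beyond the scatter). Compound 2 also carries a 4-chlorophenyl group. The other steps, a number 20.7 percentage points higher from compound 1 to compound 2 (beyond the scatter) and a number 9.1 percentage points lower from compound 1 to compound 3 (within the scatter), likewise leave compound 2 standing apart. For compound 4 a modest upward step is therefore expected, a number 18 percentage points higher from compound 3 to compound 4 (beyond the scatter). Compound 4 is thus estimated to give 18%, within a range from 2% to 38%.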

Compound 4, a percentage reported as inhibition, at one concentration (the size of the read-out at that concentration, not a potency): 2.6%
Estimate against measurement, compound 4: 15.4 percentage points above; the range from low to high includes it.
By their numbers in this assay, from the lowest: compounds 3, 4 and 1 (each within the scatter of the next); then compound 2.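

Moving from chloro to methyl on the same phenyl group gives a number 27.2 percentage points lower from compound 2 to compound 4 (beyond the scatter), so in this assay the position of the substituent alone does not carry the effect seen with the 4-chlorophenyl group. The other two steps, a number 2.6 percentage points higher from compound 3 to compound 4 (within the scatter) and a number 6.5 percentage points lower from compound 1 to compound 4 (within the scatter), leave compound 4 level with both neighbours, and among these four compounds only compound 2 stands apart. No measurement available here explains why the chloro and methyl groups differ. As far as these compounds go, whether a bromo group, an amine or a carboxylic acid at this spot on the phenyl ring would behave like chloro or like methyl stays open.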